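This account rests on a few compounds, and the source may have more. Where it says the series, first, only, none or still open, it means among the compounds named here.

Compound 1 `Cc1cc(C)c(CNC(=O)c2cccc(OC(C)C)c2C)c(=O)[nH]1` and compound 2 `Cc1cc(C)c(CN2CCc3ccc(OC(C)C)cc3C2=O)c(=O)[nH]1` were both tested in an assay on Sf9 cells for inhibition of histone-lysine N-methyltransferase EZH2 (Homo sapiens), read by scintillation counting, with a stated time of 60 min, in the presence of a further agent that is not named here; a lower number here means a stronger inhibitor, a higher number a weaker inhibitor. Compound 1 gives 1400 nM in this assay. Compound 2 gives 8100 nM in this assay. For the measured compounds named here, of these two numbers, the one for compound 1 is the lower, and the gap to compound 2 is beyond the usual scatter of such measurements, so compound 1 is the stronger inhibitor of the two; no further pairing between them is described here.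

Compound 3 `Cc1cc(C)c(CNC(=O)c2cccc(OC(C)C)c2Cl)c(=O)[nH]1` has not yet been measured in this assay. It differs from compound 1 in one place: chloro in place of methyl on an aromatic carbon. The chloro group enters on an aromatic carbon of a six-membered aromatic ring of carbon only, ortho to a large group, ortho to an isopropoxy group. Going by the values given here, nothing among the measured compounds shows what this exchange does in this assay, so the expectation rests on the change being a swap of one heavy atom for another of similar size. The step from compound 1 to compound 3 is expected to be small, a 1.3-fold higher number from compound 1 to compound 3 (0.11 log units; within the scatter), and may well stay within the scatter. Compound 3 is therefore estimated at 1800 nM, with a range from 700 nM to 4500 nM.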

Compound 3, half-maximal inhibitory concentration: 1300 nM
Estimate against measurement, compound 3: 1.4-fold (0.14 log units) above; the range from low to high includes it.
By their numbers in this assay, from the lowest: compounds 3 and 1 (each within the scatter of the next); then compound 2.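

In this assay, putting chloro in place of methyl on this aromatic carbon, ortho to an isopropoxy group, gives a 1.1-fold lower number from compound 1 to compound 3 (0.03 log units; within the scatter), so this measurement cannot tell compound 1 and compound 3 apart. Until now, nothing had shown how this position responds to any exchange; this first test shows that, on the core of compound 1, either of these two groups can occupy it with no change beyond the usual scatter. No measurement shown here explains why the two groups read alike, so the result records an outcome and not a mechanism.

On these data alone, only methyl and chloro have been seen at this position, so it remains open whether plain hydrogen, a methoxy group, an ethyl group, a nitrile or an amine would give a similar number or a clearly different one. As far as these compounds go, it also remains open whether the same exchange would read the same way in another setting, since compound 2 differs from the other two compounds in more than one place and offers no such comparison.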